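This account rests on a few compounds, and the source may have more. Where it says the series, first, only, none or still open, it means among the compounds named here.

Compound 1 `FC(F)(F)c1cccc(NC(=S)Nc2ccccc2)c1`: 39000 nM
Compound 2 `C=C(C)CNC(=S)Nc1cccc(C(F)(F)F)c1`: > 100000 nM

In an ADME assay on Vero 76 cells (Chlorocebus sabaeus) for cytotoxicity, read by crystal violet staining, with a stated time of 96 h (on this read-out higher numbers stand for lower toxicity in this test and lower numbers for higher toxicity in this test), compound 2 gives only a limit of the test, > 100000 nM, and not a true number. Compound 3 `Fc1ccccc1NC(=S)Nc1cccc(C(F)(F)F)c1` keeps the shared core and changes one group: 2-fluorophenyl in place of 2-methylprop-2-en-1-yl on an amide-type nitrogen. For the measured compounds named here, the one measured step that bears on this is an at least 2.5-fold higher number from compound 1 to compound 2 (0.40 log units; beyond the scatter), a swap away from phenyl on the same amide-type nitrogen. Compound 3 brings an aromatic ring back to that nitrogen, so a move to a lower number is expected, towards compound 1 at 39000 nM. The expected step is an at least 3.3-fold lower number from compound 2 to compound 3 (0.52 log units; beyond the scatter). Compound 3 is estimated at 30000 nM, with an expected range of 10000 nM to 80000 nM.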

Compound 3, half-maximal cytotoxic concentration: 64000 nM
The estimate for compound 3 lay 2.1-fold (0.33 log units) below the measured number; low and high end bracket the measured number.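

In this assay the swap to 2-fluorophenyl on the amide-type nitrogen gives an at least 1.5-fold lower number from compound 2 to compound 3 (0.19 log units; that floor lies within the scatter) and so cannot yet be called a real change. Fluoro in place of hydrogen on an aromatic carbon gives a 1.6-fold higher number from compound 1 to compound 3 (0.22 log units; within the scatter) and so leaves these two compounds reading alike on this test. The swap to 2-fluorophenyl has no true size, because compound 2 carries only a limit: the limit of > 100000 nM in this assay, at which 1 of the 3 values shown sits.

Still open, as far as these compounds go, is how an amine, a carboxylic acid or a longer chain in place of 2-fluorophenyl on the amide-type nitrogen would read on this test.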